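The compounds below may be only part of what the source reports. "The series", "measured", "known", "first", "only" and "open" are said of these compounds alone.

Of the compounds shown here, three built on one shared core have so far been measured in an assay on CHO cells for displacement of a labelled ligand from adenosine receptor A3 (Homo sapiens), read by scintillation counting, with a stated time of 60 min; a lower number here means a stronger inhibitor, a higher number a weaker inhibitor. Compound 1 `O=C(CCCc1ccccc1)Nc1nc2ccsc2c(=O)s1` gives > 1000 nM in this assay, and this is a limit of the assay rather than a number. Compound 2 `O=C(CCCc1ccccc1)Nc1nc2ccc(Cl)cc2c(=O)s1` gives > 1000 nM in this assay, again a limit and not a number. Compound 3 `COc1cccc(/C=C/CC(=O)Nc2nc3ccccc3c(=O)s2)c1` is the only one of the three with a real number: in this assay compound 3 gives 115 nM. Compound 3 therefore stands by itself, since the values of the other two compounds sit at the limit of > 1000 nM in this assay, at which 2 of the 3 values shown sit.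

Compound 4 `O=C(C/C=C/c1ccc(Cl)c(Cl)c1)Nc1nc2ccccc2c(=O)s1` has not yet been measured. It differs from compound 3 in a single place: 3,4-dichlorophenyl in place of 3-methoxyphenyl on a double-bonded chain carbon bound to a double-bonded chain carbon. Within the data shown here, no pair of measured compounds shows an exchange of this kind, so there is no measured step to lean on. The step from compound 3 to compound 4 is expected to be modest, a 1.0-fold lower number from compound 3 to compound 4 (0.02 log units; within the scatter), and not clearly beyond the usual scatter in either direction. Compound 4 is accordingly estimated at 110 nM in this assay, with a range from 30 nM to 450 nM.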

Compound 4, inhibition constant: > 1000 nM
Compound 4: a limit, no number; the forecaster's own chance of this, stated with the estimate: 10%; at least 9.0-fold (0.95 log units) between middle value and limit.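

In this assay, the exchange of 3-methoxyphenyl for 3,4-dichlorophenyl on a double-bonded chain carbon bound to a double-bonded chain carbon gives an at least 8.6-fold higher number from compound 3 to compound 4 (0.93 log units; beyond the scatter) and so shows that this position does not take every substituted phenyl group alike. Among these compounds, until now compound 3 was the only compound with a number and no pair differing in one place could be read, whereas here the shared core and the chain stay the same and only the group at the end of the chain changes. The size of the step is only a lower bound, since compound 4 gives a limit and not a number, and it joins the other compounds held at that limit: the limit of > 1000 nM in this assay, at which 3 of the 4 values shown sit.

Going by these compounds, it remains open whether the loss of the methoxy group or the arrival of the two chlorine atoms accounts for the step, which a phenyl group carrying a single chlorine or a plain unsubstituted phenyl group at this place could help to separate. Also open, on these data alone, is how much the double bond itself contributes, and whether a saturated or longer chain carrying 3-methoxyphenyl would hold a number in this range.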